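Swapping the Sulfonamide Substituent in a Deacetylase Inhibitor

The source may report more compounds than this note shows. Statements on the series, on what has been measured and on what is new or still open speak of the compounds shown alone.

Of the compounds shown here, three have so far been measured in an assay on HEK293 cells for inhibition of protein deacetylase HDAC6 (Homo sapiens); on this read-out higher numbers stand for weaker inhibition and lower numbers for stronger inhibition. Compound 2 `CCSC(=S)SCC(=O)c1cccc(S(=O)(=O)Nc2cccc(C(N)=O)c2)c1` gives 181 nM, the lowest number of the three. Compound 3 `CCSC(=S)SCC(=O)c1ccc(C(=O)Nc2ccc(Cl)cc2)cc1` gives 1450 nM, and compound 1 `CCOC(=O)SCC(=O)c1ccc(OC)cc1` gives 5360 nM; both gaps from compound 2 lie beyond the usual scatter of this assay, so compound 2 is the strongest inhibitor among the measured set.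

Compound 4 `CCSC(=S)SCC(=O)c1cccc(S(=O)(=O)Nc2ccc(OC)cc2)c1` has not yet been measured. It differs from compound 2 in one place: 4-methoxyphenyl in place of 3-carbamoylphenyl on a sulfonamide nitrogen. Within the data shown here, the hydrogen-bond donor counted in the leaving group has no counterpart in the entering group, while an acceptor remains. Among the measured compounds shown here, no measured pair shows this same exchange, so the size of the step cannot be read from existing numbers; a moderate weakening, somewhat beyond the scatter, is expected. Compound 4 is estimated to give about 450 nM, in a range from 150 nM to 1400 nM. The step this estimate implies, a 2.5-fold higher number from compound 2 to compound 4 (0.40 log units; beyond the scatter), is expected to stay smaller than the gaps already seen.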

Compound 4, half-maximal inhibitory concentration: 519 nM
Compound 4: the middle estimate sits 1.2-fold (0.06 log units) below what was measured, and the stated range covers the measured number.
By their numbers in this assay, from the lowest: compound 2; then compound 4; then compound 3; then compound 1.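

Replacing 3-carbamoylphenyl with 4-methoxyphenyl on a sulfonamide nitrogen gives a 2.9-fold higher number from compound 2 to compound 4 (0.46 log units; beyond the scatter) in this assay, a modest but real step. Among these compounds, this is the first pair in the set that differs in only one place, so it is the first direct sign that the group on this nitrogen affects the number, which the earlier compounds could not show. Nothing available explains why the number rises with this change.

The exchange alters the group and its numbered position together, so 3-methoxyphenyl or 4-carbamoylphenyl would be needed to separate the two. On these data alone, how far this position tolerates other groups also stays open, for example a phenyl ring carrying a carboxylic acid or an amine.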